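Dichlorophenyl in Place of Phenyl on an Amide Side Chain

A few compounds are considered here, and "the series" means these few. Any claim that something is new, unique, unknown or untested is made for them only; others in the source may bear on it.

Measured compounds:
- compound 1, `CN(C(=O)CCCc1ccccc1)c1nc2ccccc2c(=O)s1`: > 10000 nM in an assay on membranes from brain for displacement of a labelled ligand from adenosine receptor A1 (Rattus norvegicus), read by scintillation counting, with a stated time of 90 min; a lower number here means a stronger inhibitor, a higher number a weaker inhibitor
- compound 2, `O=C(CCCc1ccccc1)Nc1nc2ccccc2c(=O)s1`: 229 nM
- compound 3, `O=C(C/C=C/c1ccccc1)Nc1nc2ccccc2c(=O)s1`: 53 nM

All three share one core and differ only in the side chain attached through the amide. For compound 1 the result in this assay is a limit rather than a number, and it sits at the limit of > 10000 nM in this assay, at which 1 of the 3 values shown sits. Among the measured compounds shown here, the one measured step between neighbouring compounds is an at least 43-fold lower number from compound 1 to compound 2 (1.64 log units; beyond the scatter). Compound 3 gives the lowest of the two numbers shown; compound 2 stands nearest, and that gap lies beyond the scatter.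

The unmeasured compound 4, `O=C(C/C=C/c1ccc(Cl)c(Cl)c1)Nc1nc2ccccc2c(=O)s1`, differs from compound 3 in one place: 3,4-dichlorophenyl in place of phenyl on a double-bonded chain carbon bound to a double-bonded chain carbon. For the measured compounds named here, no measured step touches this part of the molecule; the single step known changes the amide nitrogen, not the aromatic ring at the end of the chain. Any expectation therefore rests on compound 3 alone. Compound 4 is estimated to stay close to compound 3, with a step of a 1.3-fold lower number from compound 3 to compound 4 (0.12 log units; within the scatter) expected, within the usual scatter. The estimate for compound 4 in this assay is 40 nM, with a range from 10 nM to 200 nM.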

Compound 4, inhibition constant: >= 1500 nM
Compound 4 was reported as a limit; the forecaster's own chance of this, stated with the estimate: 3%; at least 37-fold (1.57 log units) between middle value and limit.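

In this assay, 3,4-dichlorophenyl in place of phenyl gives an at least 28-fold higher number from compound 3 to compound 4 (1.45 log units; beyond the scatter), the first sign that the aromatic ring at the end of the side chain is as sensitive to change as the amide nitrogen, the only place that a measured step had touched before. For compound 4 the result is a limit rather than a number: the limit of >= 1500 nM in this assay, at which 1 of the 4 values shown sits. The shared core, the amide and the double bond in the chain are all unchanged between these two compounds, so this large loss goes with the swap of phenyl for 3,4-dichlorophenyl alone, although the data give no reason for it.

The compounds shown leave open whether both chlorine atoms are needed for this loss, or whether a single chlorine, a fluorine or a methoxy group on the ring would produce it as well. They also leave open whether the same ring change would have a similar result on the chain of compound 2, and how an amine or a carboxylic acid on the ring would fare.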